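Naphthyl Sulfonamide Replaces Difluorophenyl on the Shared Core

The source may hold more compounds than are shown below. What is called first, only, known or untested is meant among the compounds shown, and "the series" means these compounds.

Two sulfonamides of the shared core have been measured in an assay on MDA-MB-231 cells for binding affinity to C-X-C chemokine receptor type 4 (Homo sapiens), read by microscopy, with stated times of 10 min and 30 min; a lower number here means that less compound is needed, a higher number that more compound is needed for the effect. Compound 1 `Cc1ccccc1S(=O)(=O)NCc1ccc(CNC(=O)c2ccc(CNc3ncccn3)cc2)cc1` gives 10 nM there, and compound 2 `O=C(NCc1ccc(CNS(=O)(=O)c2ccc(F)c(F)c2)cc1)c1ccc(CNc2ncccn2)cc1` gives 100 nM. For the measured compounds named here, compound 2 therefore holds the highest of the two numbers so far; its only neighbour is compound 1, and the step of a 10-fold higher number from compound 1 to compound 2 (1.00 log units; beyond the scatter) separates them, a difference that is beyond the scatter.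

The next compound, compound 3 `O=C(NCc1ccc(CNS(=O)(=O)c2cccc3ccccc23)cc1)c1ccc(CNc2ncccn2)cc1`, keeps everything in compound 2 except the aryl group on the sulfonyl sulfur: naphthalen-1-yl in place of 3,4-difluorophenyl on a sulfonyl sulfur. Going by the values given here, the one measured step that bears on this position is the one from compound 1 to compound 2, a swap of one aromatic group for another on the same sulfonyl sulfur, which moved this assay by a 10-fold higher number from compound 1 to compound 2 (1.00 log units; beyond the scatter). That shows the aryl on the sulfonyl sulfur can shift the number by that much in either direction. Among the compounds with values here, with no second naphthyl compound for comparison, the expected step is a 3.3-fold lower number from compound 2 to compound 3 (0.52 log units; beyond the scatter), a modest move toward a lower number, carrying real uncertainty. Compound 3 is thus estimated at 30 nM, within a range from 8 nM to 120 nM.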

Compound 3, effective concentration (reported as EC, without a stated level of effect): 1000 nM
Beside the measured number, compound 3's estimate is 33-fold (1.52 log units) below it; the measured number lies above the stated range.
By their numbers in this assay, from the lowest: compound 1; then compound 2; then compound 3.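

Naphthalen-1-yl on the sulfonyl sulfur gives a 10-fold higher number from compound 2 to compound 3 (1.00 log units; beyond the scatter) in this assay, so the second aryl swap at this position moves the number the same way as the first. Taken against the 2-methylphenyl group, the same change gives a 100-fold higher number from compound 1 to compound 3 (2.00 log units; beyond the scatter), which shows that the choice of aryl group alone, with the rest of the shared core unchanged, spans a far wider range than any single step had shown. Naphthalen-1-yl is the only one of the three groups with 2 six-membered aromatic rings, and it carries the highest number, but one compound sets no rule, and nothing available explains why this group stands where it does.

The compounds shown leave open whether the second ring itself matters or only how it is attached, which naphthalen-2-yl on the same sulfonyl sulfur would speak to. They also leave open where an unsubstituted phenyl or a 2-chlorophenyl group would fall, and so whether the methyl of compound 1 has any part in its low number.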